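Adding a second methoxy to compound 3

This account rests on a few compounds, and the source may have more. Where it says the series, first, only, none or still open, it means among the compounds named here.

For the measured compounds named here, in a functional assay on SK-N-MC cells (Homo sapiens) for cytotoxicity, read by MTT assay, with a stated time of 72 h (a lower number here means a stronger inhibitor, a higher number a weaker inhibitor), compound 3 (`COc1ccccc1/C=C/c1nc(Cl)c2ccccc2n1`) gives 580 nM, the lowest number so far. Compound 1 (`O=c1[nH]c(/C=C/c2ccccc2)nc2ccccc12`) gives 1390 nM, and compound 2 (`Clc1nc(/C=C/c2ccccc2)nc2ccccc12`) gives 4960 nM. Compound 4 (`COc1ccc(/C=C/c2nc(Cl)c3ccccc3n2)c(OC)c1`) carries one further change on compound 3, a methoxy in place of hydrogen on an aromatic carbon. Going by the values given here, one measured step bears on this, an 8.6-fold lower number from compound 2 to compound 3 (0.93 log units; beyond the scatter), which was also a methoxy in place of hydrogen. That single step does not show whether a second methoxy adds to the first. A smaller move towards a lower number is therefore expected in this assay, possibly none beyond the scatter. The estimated step is a 1.4-fold lower number from compound 3 to compound 4 (0.14 log units; within the scatter). For compound 4 the estimated value is 420 nM, with an expected range of 140 nM to 1250 nM.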

Compound 4, half-maximal inhibitory concentration: 1750 nM
The estimate for compound 4 lay 4.2-fold (0.62 log units) below the measured number; measured number outside the range, above it.
By their numbers in this assay, from the lowest: compound 3; then compounds 1 and 4 (each within the scatter of the next); then compound 2.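

In this assay, a second methoxy does not repeat the direction of the first: after an 8.6-fold lower number from compound 2 to compound 3 (0.93 log units; beyond the scatter), the new group, meta to a methoxy group and para to a large group, gives a 3.0-fold higher number from compound 3 to compound 4 (0.48 log units; beyond the scatter). The same replacement therefore does not act additively across these compounds, and its outcome differs between the two places on the ring.

As far as these compounds go, whether a methoxy at this place would raise the number without the first methoxy remains open, as does how a hydroxyl or an amine there would compare. Nothing measured here gives a reason for the reversal.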